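A few compounds are considered here, and "the series" means these few. Any claim that something is new, unique, unknown or untested is made for them only; others in the source may bear on it.

Compound 1 `COc1cc([C@@H]2OC(=O)O[C@H]2C)cc(OC)c1C`: 40100 nM
Compound 2 `C/C=C/c1cc(OC)c(O[C@H](C)[C@H](OC(C)=O)c2cc(OC)c(OC)c(OC)c2)c(OC)c1`: 16900 nM

In a functional assay on RAW264.7 cells (Mus musculus) for inhibition, read by Griess assay, with a stated time of 24 h, in the presence of a further agent that is not named here (on this read-out higher numbers stand for weaker inhibition and lower numbers for stronger inhibition), compound 2 gives 16900 nM, the lower of the two numbers. Compound 1 gives 40100 nM. The gap between these two compounds lies beyond the usual scatter. The next compound is compound 3 `C=CCc1cc(OC)c(O[C@H](C)[C@H](OC(C)=O)c2cc(OC)c(OC)c(OC)c2)c(OC)c1`. It has allyl in place of prop-1-en-1-yl on an aromatic carbon, meta to two methoxy groups and para to a large group (allyl in place of prop-1-en-1-yl on an aromatic carbon). The two structures have the same atoms, joined differently. For the measured compounds named here, no measured pair isolates this change, so the expectation rests only on compound 2 at 16900 nM and the change itself. No step beyond the scatter is expected in this assay. The estimated change is a 1.2-fold higher number from compound 2 to compound 3 (0.07 log units; within the scatter). Compound 3 is expected at about 20000 nM, with an estimated range of 9000 nM to 45000 nM.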

Compound 3, half-maximal inhibitory concentration: 10400 nM
For compound 3 the middle estimate is 1.9-fold (0.28 log units) above the measured one; measured number inside the range.
By their numbers in this assay, from the lowest: compounds 3 and 2 (each within the scatter of the next); then compound 1.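

In this assay, allyl in place of prop-1-en-1-yl on this aromatic carbon gives a 1.6-fold lower number from compound 2 to compound 3 (0.21 log units; within the scatter). For the compounds shown here, this is the first reading at this position, and it shows that this rearrangement of the same atoms within the three-carbon substituent leaves compound 2 and compound 3 inseparable on this read-out, so the position of the double bond in the chain does not register here. No available data offer an explanation for this outcome.

The compounds shown cover only these two unsaturated three-carbon substituents at this position, so the effect of a saturated propyl group, a longer chain, an amine or a carboxylic acid on this carbon remains open. As far as these compounds go, whether this indifference to the change would hold in any other assay also remains open.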